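A few compounds are considered here, and "the series" means these few. Any claim that something is new, unique, unknown or untested is made for them only; others in the source may bear on it.

Measured in a functional assay on HepG2 cells (Homo sapiens) for antiproliferative activity, read by MTT assay, with a stated time of 48 h; on this read-out lower numbers stand for stronger inhibition and higher numbers for weaker inhibition:
- Compound 1 `O=C(/C=C/c1c[nH]c2ccccc12)c1ccncc1`: 49300 nM
- Compound 2 `O=C(/C=C/c1cn(S(=O)(=O)c2ccc([N+](=O)[O-])cc2)c2ccccc12)c1ccncc1`: 18300 nM
- Compound 3 `O=C(/C=C/c1cn(S(=O)(=O)c2cccc3ccccc23)c2ccccc12)c1ccncc1`: 62900 nM

Compound 3, at 62900 nM, lies within the usual scatter of compound 1, at 49300 nM, so these two cannot be told apart. Compound 2 gives a clearly lower number, at 18300 nM.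

The next compound to be tested is compound 4 `O=C(/C=C/c1cn(S(=O)(=O)c2ccc(Cl)cc2)c2ccccc12)c1ccncc1`, which has 4-chlorophenyl in place of naphthalen-1-yl on a sulfonyl sulfur.

For the measured compounds named here, only one measured step bears on this change: a 3.4-fold higher number from compound 2 to compound 3 (0.54 log units; beyond the scatter). There, naphthalen-1-yl took the place of 4-nitrophenyl and the number rose. Compound 4 goes the opposite way, from naphthalen-1-yl to a group with one six-membered aromatic ring, so a fall of similar, modest size seems reasonable. Going by the values given here, no measured compound carries chlorine, however, so this rests on thin evidence.

The expected step is a 2.9-fold lower number from compound 3 to compound 4 (0.46 log units; beyond the scatter), towards a lower number. For compound 4 the estimated value is 22000 nM, with an expected range from 7000 nM to 60000 nM.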

Compound 4, half-maximal inhibitory concentration: 35100 nM
The estimate for compound 4 lay 1.6-fold (0.20 log units) below the measured number; measured number inside the range.
By their numbers in this assay, from the lowest: compounds 2, 4, 1 and 3 (each within the scatter of the next, the first and the last beyond it).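

In this assay, 4-chlorophenyl in place of naphthalen-1-yl on the sulfonyl sulfur gives a 1.8-fold lower number from compound 3 to compound 4 (0.25 log units; within the scatter), and chloro in place of nitro on an aromatic carbon gives a 1.9-fold higher number from compound 2 to compound 4 (0.28 log units; within the scatter). Compound 4 therefore cannot be told apart from either compound 3 or compound 2, although those two are clearly separated, so going from two aromatic rings to one on this sulfur is not shown to be a real gain by this step alone. Nothing available here explains these numbers.

The compounds shown leave open how a plain phenyl, a 4-methoxyphenyl or a simple methyl on the sulfonyl sulfur would read. Going by these compounds, it also remains open whether an amine in place of the chloro would fall nearer compound 2 or compound 3.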